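The source may report more compounds than this note shows. Statements on the series, on what has been measured and on what is new or still open speak of the compounds shown alone.

Compound 1, `CC(C)(C)c1ccc(Nc2ccc3c(c2)C(=O)N(C2CCC(=O)NC2=O)C3=O)cc1`, sits at the top of the three numbers in an assay on FRT-Jurkat cells for inhibition of nuclear factor NF-kappa-B complex (Homo sapiens), read by flow cytometry, with a stated time of 24 h, tested at 10 uM (on this read-out lower numbers stand for less inhibition and higher numbers for more inhibition at the one concentration tested (going by the name of the read-out)), where compound 1 gives 17%. Its nearest neighbour is compound 3, `Cc1ccc(Nc2cccc3c2C(=O)N(C2CCC(=O)NC2=O)C3=O)cc1`, which in this assay gives 9%, a number that lies within the scatter of compound 1; the furthest is compound 2, `O=C1CCC(N2C(=O)c3cccc(Nc4ccc(O)cc4)c3C2=O)C(=O)N1`, which in this assay gives 4%, beyond the scatter below compound 1. Within the data shown here, the only step that can be followed runs a number 5 percentage points higher from compound 2 to compound 3 (within the scatter), and it stays within the scatter.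

Compound 4, `CCCc1ccc(Nc2ccc3c(c2)C(=O)N(C2CCC(=O)NC2=O)C3=O)cc1`, differs from compound 1 in one place: propyl in place of tert-butyl on an aromatic carbon. Among the measured compounds shown here, no measured step trades one alkyl group for another; the closest guide is the step from compound 2 to compound 3, which exchanged one small group for another and moved nothing beyond the scatter. On that footing the step from compound 1 to compound 4 is expected to be small, a number 3 percentage points lower from compound 1 to compound 4 (within the scatter), with no clear direction. Compound 4 is therefore estimated at 14%, within a range from 2% to 28%.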

Compound 4, a percentage reported as inhibition, at one concentration (the size of the read-out at that concentration, not a potency): 10%
Estimate against measurement, compound 4: 4 percentage points above, and the stated range covers the measured number.
By their numbers in this assay, from the lowest: compounds 2, 3, 4 and 1 (each within the scatter of the next, the first and the last beyond it).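

Among these compounds, on the aromatic carbon para to a large group, the exchange of tert-butyl for propyl runs a number 7 percentage points lower from compound 1 to compound 4 (within the scatter) and is the first measured swap of one alkyl group for another at this place. In this assay these two groups, which differ by one carbon and carry no ring, hydrogen-bond donor, hydrogen-bond acceptor or net charge, therefore cannot be told apart. Nothing measured here accounts for this result.

On these data alone, what an amine, a carboxylic acid or a longer alkyl chain such as hexyl would do at this place remains open. As far as these compounds go, it also remains open whether compound 1 and compound 4 would separate in this assay at any concentration other than the one tested.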